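A Dichlorobenzyl Variant Measured Beside Its Two Neighbours

A few compounds are considered here, and "the series" means these few. Any claim that something is new, unique, unknown or untested is made for them only; others in the source may bear on it.

In a functional assay on MCF7 cells (Homo sapiens) for cytotoxicity, read by MTT assay, with a stated time of 24 h (a lower number here means a stronger inhibitor, a higher number a weaker inhibitor), compound 1 `Cn1nc(-c2ccc(C(F)(F)F)cc2)cc1-c1nnc(S)o1` reaches only the limit of the measurement, > 100000 nM. The two substituted compounds carry numbers: compound 2 `Cn1nc(-c2ccc(C(F)(F)F)cc2)cc1-c1nnc(SCc2c(F)cccc2F)o1` gives 46200 nM, and compound 3 `Cn1nc(-c2ccc(C(F)(F)F)cc2)cc1-c1nnc(SCCOc2ccccc2F)o1` gives 33300 nM. Compound 3 thus holds the lower of the two numbers, with compound 2 nearest and within the scatter. The steps of an at least 2.1-fold lower number from compound 1 to compound 2 (0.33 log units; beyond the scatter) and an at least 3.0-fold lower number from compound 1 to compound 3 (0.47 log units; beyond the scatter) show that placing a substituent on the sulfur moved the number, whereas a 1.4-fold lower number from compound 2 to compound 3 (0.14 log units; within the scatter) shows that exchanging one such substituent for another did not move it beyond the scatter. Compound 4 `Cn1nc(-c2ccc(C(F)(F)F)cc2)cc1-c1nnc(SCc2cccc(Cl)c2Cl)o1` carries a further exchange of the same kind: 2,3-dichlorophenyl in place of (2-fluorophenoxy)methyl on a saturated chain carbon bound to a sulfur. For the measured compounds named here, the only comparable measured step, a 1.4-fold lower number from compound 2 to compound 3 (0.14 log units; within the scatter), stayed within the scatter, so in this assay no step beyond the scatter is expected from compound 3 to compound 4. Compound 4 is therefore estimated at 40000 nM, within a range from 15000 nM to 100000 nM, which corresponds to an expected step of a 1.2-fold higher number from compound 3 to compound 4 (0.08 log units; within the scatter).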

Compound 4, half-maximal inhibitory concentration: 60200 nM
Beside the measured number, compound 4's estimate is 1.5-fold (0.18 log units) below it; the range from low to high includes it.
By their numbers in this assay, from the lowest: compounds 3, 2 and 4 (each within the scatter of the next). At a limit, above all of these: compound 1.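

In this assay, the 2,3-dichlorobenzyl group on the sulfur falls in with the two earlier substituents: a 1.8-fold higher number from compound 3 to compound 4 (0.26 log units; within the scatter) and a 1.3-fold higher number from compound 2 to compound 4 (0.11 log units; within the scatter). At this place, on a saturated chain carbon bound to a sulfur, neither giving up the oxygen of the (2-fluorophenoxy)methyl group nor exchanging 2,6-difluorophenyl for 2,3-dichlorophenyl moved the number beyond the scatter. Unlike the earlier steps away from compound 1, an at least 1.6-fold lower number from compound 1 to compound 4 (0.22 log units; that floor lies within the scatter) does not establish a change, because the value of compound 1 is a limit: the limit of > 100000 nM in this assay, at which 1 of the 4 values shown sits.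

All the substituted compounds shown carry a halogenated aromatic ring on the chain. From the compounds shown here alone, whether an amine, a carboxylic acid or an unsubstituted phenyl ring at this place would leave this narrow band remains open.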